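The compounds below may be only part of what the source reports. "The series", "measured", "known", "first", "only" and "open" are said of these compounds alone.

Measured compounds:
compound 1, `Cc1c(C)c2c(c(C)c1O)CCC(C)(C(=O)Nc1ccncc1)O2`, 2300 nM;
compound 2, `Cc1c(C)c2c(c(C)c1O)CCC(C)(C(=O)Nc1ccccn1)O2`, 1800 nM;
compound 3, `Cc1c(C)c2c(c(C)c1O)CCC(C)(CNc1ccncc1)O2`, 16000 nM.

All three were tested in a functional assay (brain) for inhibition, with Rattus norvegicus as the target; on this read-out lower numbers stand for stronger inhibition and higher numbers for weaker inhibition. Compound 1 and compound 2 differ by a single change, (pyridin-2-yl in place of pyridin-4-yl on an amide-type nitrogen), and the step of a 1.3-fold lower number from compound 1 to compound 2 (0.11 log units; within the scatter) is small. Compound 3 stands apart: the difference between its core and the core of compound 1 is not broken down here, but compound 3 gives a clearly higher number than both others. Compound 4, `Cc1c(C)c2c(c(C)c1O)CCC(C)(CNc1ccccn1)O2`, is not yet measured; it differs from compound 3 by pyridin-2-yl in place of pyridin-4-yl on an amine nitrogen. This is the same kind of change as from compound 1 to compound 2, not the same one: there the place was an amide-type nitrogen whose other neighbours are a carbonyl carbon, here an amine nitrogen whose other neighbours are a saturated chain carbon. Because the step of a 1.3-fold lower number from compound 1 to compound 2 (0.11 log units; within the scatter) stayed within the scatter, a similarly small step is expected here, a 1.3-fold lower number from compound 3 to compound 4 (0.12 log units; within the scatter), resting on that single earlier pair. Compound 4 is therefore estimated at 12000 nM, most likely between 6000 nM and 28000 nM.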

Compound 4, half-maximal inhibitory concentration: 200 nM
Beside the measured number, compound 4's estimate is 60-fold (1.78 log units) above it, and the stated range ends above it.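

Placing pyridin-2-yl instead of pyridin-4-yl on the amine nitrogen gave an 80-fold lower number from compound 3 to compound 4 (1.90 log units; beyond the scatter) in this assay, so on this core the change is far from silent. The same change does not carry over with the same size from one core to the other: the same change on two cores in this assay, a 1.3-fold lower number (0.11 log units; within the scatter) from compound 1 to compound 2 and an 80-fold lower number (1.90 log units; beyond the scatter) from compound 3 to compound 4, 63-fold (1.80 log units) apart, beyond the scatter of two such steps This shows that, in these two pairs, the size of the step depends on the core that carries it, but two pairs give no rule for other cores and do not show what causes the gap.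

The compounds shown leave open whether phenyl or pyridin-3-yl on the amine nitrogen would give a number like that of compound 3 or that of compound 4. They also leave open what a longer chain carrying that nitrogen would do.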